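This account rests on a few compounds, and the source may have more. Where it says the series, first, only, none or still open, it means among the compounds named here.

Measured in a functional assay on C8166 cells (Homo sapiens) for cytotoxicity, read by MTT assay; a higher number here means that more compound is tolerated, a lower number that less compound is tolerated
Compound 1 `Cc1cc(C)cc(C(=O)Nc2cc(Cl)ccc2OCC(=O)Nc2ccc(S(N)(=O)=O)cc2C)c1` gives 36500 nM
Compound 2 `Cc1cc(S(N)(=O)=O)ccc1NC(=O)COc1ccc(Cl)cc1NC(=O)c1ccc(Cl)cc1Cl` gives 61100 nM

For the measured compounds named here, compound 2 (61100 nM) lies within the scatter of compound 1, so the two cannot be told apart in this assay (the only numbers so far). Compound 3 `Cc1cc(S(N)(=O)=O)ccc1NC(=O)COc1ccc(Cl)cc1NC(=O)c1cc(Cl)cc(Cl)c1` has the same atoms as compound 2, joined differently (3,5-dichlorophenyl in place of 2,4-dichlorophenyl on a carbonyl carbon). Going by the values given here, only one measured step bears on this carbonyl carbon (a 1.7-fold higher number from compound 1 to compound 2 (0.22 log units; within the scatter)). It stayed within the scatter, so no step beyond the scatter is expected here. The expected step is small (a 1.4-fold lower number from compound 2 to compound 3 (0.13 log units; within the scatter)). Compound 3 is expected at 45000 nM (estimated range 20000 nM to 100000 nM).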

Compound 3, half-maximal cytotoxic concentration: 72400 nM
Compound 3: the middle estimate sits 1.6-fold (0.21 log units) below what was measured; low and high end bracket the measured number.
By their numbers in this assay, from the lowest: compounds 1, 2 and 3 (each within the scatter of the next).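

In this assay, the same atoms rearranged on this carbonyl carbon, 3,5-dichlorophenyl in place of 2,4-dichlorophenyl, give a 1.2-fold higher number from compound 2 to compound 3 (0.07 log units; within the scatter), while chlorines in place of the methyls of 3,5-dimethylphenyl give a 2.0-fold higher number from compound 1 to compound 3 (0.30 log units; within the scatter). The three groups shown at this place therefore cannot be told apart in this assay, whether the ring carries chlorine or methyl and wherever the chlorines sit among these two patterns. Nothing available explains these numbers. Still open, from the compounds shown here alone, is whether a different group on this carbonyl carbon, such as a pyridine ring or a phenyl ring bearing a carboxylic acid or an amine, would move the number beyond the scatter.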